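Fluoro for methyl in compound 4

The source may hold more compounds than are shown below. What is called first, only, known or untested is meant among the compounds shown, and "the series" means these compounds.

In an ADME assay on L929 cells (Mus musculus) for cytotoxicity, read by MTT assay, with a stated time of 72 h (a lower number here means a stronger inhibitor, a higher number a weaker inhibitor), compound 1 `Cc1ccc(S(=O)(=O)n2cc(COC3=C/C(=N\c4ccccc4)c4ccccc4C3=O)nn2)cc1` gives only the limit > 20000 nM and no number. In this assay compound 2 `CC(=O)c1ccc(/N=C2\C=C(OCc3cn(S(=O)(=O)c4ccc(C)cc4)nn3)C(=O)c3ccccc32)cc1` gives 10800 nM and compound 3 `Cc1ccc(/N=C2\C=C(OCc3cn(S(=O)(=O)c4ccc(C)cc4)nn3)C(=O)c3ccccc32)cc1` gives 17700 nM as its value. The gap between these two is a 1.6-fold higher number from compound 2 to compound 3 (0.21 log units; within the scatter) and compound 3 therefore stands level with compound 2. The other two steps, an at least 1.1-fold lower number from compound 1 to compound 3 (0.05 log units; that floor lies within the scatter) and an at least 1.8-fold lower number from compound 1 to compound 2 (0.26 log units; that floor lies within the scatter) for acetyl, show no larger size either.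

Compound 4 `Cc1ccc(S(=O)(=O)n2cc(COC3=C/C(=N\c4ccc(F)cc4)c4ccccc4C3=O)nn2)cc1` carries fluoro in place of methyl on an aromatic carbon, para to a large group (fluoro in place of methyl on an aromatic carbon). Given a 1.6-fold higher number from compound 2 to compound 3 (0.21 log units; within the scatter) at this same place, no change beyond the scatter is expected in this assay here. The estimated change is a 1.1-fold lower number from compound 3 to compound 4 (0.04 log units; within the scatter) in size. Compound 4 is expected at 16000 nM (estimated range 9000 nM to 28000 nM).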

Compound 4, half-maximal inhibitory concentration: > 20000 nM
Compound 4: a limit, no number (the forecaster's own chance of this, stated with the estimate: 35%); at least 1.2-fold (0.09 log units) between middle value and limit.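

Compound 4 gives only a limit in this assay, > 20000 nM. On the aromatic carbon para to a large group, fluoro gives an at least 1.1-fold higher number from compound 3 to compound 4 (0.05 log units; that floor lies within the scatter) and an at least 1.8-fold higher number from compound 2 to compound 4 (0.26 log units; that floor lies within the scatter), so neither step shows a change beyond the scatter, while the step from compound 1 cannot be read. This place now holds a second compound at the limit: the limit of > 20000 nM in this assay, at which 2 of the 4 values shown sit.

As far as these compounds go, the true size of these steps stays open. So does whether an amine or a carboxylic acid at this place would give a number clearly apart from compound 2 and compound 3.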